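The source may report more compounds than this note shows. Statements on the series, on what has been measured and on what is new or still open speak of the compounds shown alone.

Compound 1 `Clc1ccc(-c2nnc(SCCCN3CCN(c4nc5ccccc5o4)CC3)o2)cc1`: 101000 nM
Compound 2 `Brc1ccc(-c2nnc(SCCCN3CCN(c4nc5ccccc5o4)CC3)o2)cc1`: 187000 nM
Compound 3 `CC(C)(C)Oc1ccc(-c2nnc(SCCCN3CCN(c4nc5ccccc5o4)CC3)o2)cc1`: 269000 nM

In a functional assay on HeLa cells (Homo sapiens) for inhibition, read by MTT assay, with a stated time of 72 h (a higher number here means a weaker inhibitor, a lower number a stronger inhibitor), compound 3 gives 269000 nM. That number sits close to the value for compound 2, as a 1.4-fold higher number from compound 2 to compound 3 (0.16 log units; within the scatter) shows, but is separated from the value for compound 1, as a 2.7-fold higher number from compound 1 to compound 3 (0.43 log units; beyond the scatter) shows. Compound 4 `c1ccc(-c2nnc(SCCCN3CCN(c4nc5ccccc5o4)CC3)o2)cc1` differs from compound 3 by hydrogen in place of tert-butoxy on an aromatic carbon. Going by the values given here, no measured step swaps a group for hydrogen. The nearest guides are a 1.9-fold higher number from compound 1 to compound 2 (0.27 log units; within the scatter), a 2.7-fold higher number from compound 1 to compound 3 (0.43 log units; beyond the scatter) and a 1.4-fold higher number from compound 2 to compound 3 (0.16 log units; within the scatter), and all of them are small. A small move to a lower number is therefore expected in this assay, probably within the scatter. The expected step is a 1.6-fold lower number from compound 3 to compound 4 (0.20 log units; within the scatter). The estimate for compound 4 is 170000 nM, with an expected range of 75000 nM to 380000 nM.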

Compound 4, half-maximal inhibitory concentration: 67000 nM
Estimate against measurement, compound 4: 2.5-fold (0.40 log units) above; measured number outside the range, below it.
By their numbers in this assay, from the lowest: compounds 4, 1, 2 and 3 (each within the scatter of the next, the first and the last beyond it).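

In this assay, compound 4 shows this position with no group on it, and hydrogen in place of tert-butoxy gives a 4.0-fold lower number from compound 3 to compound 4 (0.60 log units; beyond the scatter), while hydrogen in place of bromo gives a 2.8-fold lower number from compound 2 to compound 4 (0.45 log units; beyond the scatter). Hydrogen in place of chloro gives a 1.5-fold lower number from compound 1 to compound 4 (0.18 log units; within the scatter), so among these four compounds, neither tert-butoxy nor bromo gives a lower number than hydrogen, and chloro cannot be told apart from it. Nothing available explains these differences. Going by these compounds, whether an amine or a carboxylic acid on this aromatic carbon would give a lower number remains open.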